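Amide amine variation on a trifluoromethyl-bearing shared core

This account rests on a few compounds, and the source may have more. Where it says the series, first, only, none or still open, it means among the compounds named here.

Measured so far:
compound 1, `Cn1c(-c2ccc([N+](=O)[O-])cc2)nc2cc(C(F)(F)F)ccc21`: >= 100000 nM
compound 2, `Cn1c(-c2ccc(NC(=O)CN3CCCC3)cc2)nc2cc(C(F)(F)F)ccc21`: 16000 nM

In an ADME assay on MT4 cells (Homo sapiens) for cytotoxicity, read by MTT assay, with a stated time of 96 h (on this read-out lower numbers stand for higher toxicity in this test and higher numbers for lower toxicity in this test), compound 1 returns only a limit, >= 100000 nM, not a number (the limit of >= 100000 nM in this assay, at which 1 of the 2 values shown sits). For the measured compounds named here, compound 2 gives 16000 nM in this assay and is the only number in hand. Going by the values given here, the one measured step, an at least 6.2-fold lower number from compound 1 to compound 2 (0.79 log units; beyond the scatter), exchanges the nitro for the whole amide-bearing side chain.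

Compound 3, `CCN(CC)CC(=O)Nc1ccc(-c2nc3cc(C(F)(F)F)ccc3n2C)cc1`, differs from compound 2 by diethylamino in place of pyrrolidin-1-yl on a saturated chain carbon bound to a carbonyl carbon. Among the compounds with values here, no measured step touches this exchange of one amine for another; the step from compound 1 to compound 2 says nothing about the amine within the amide, so it gives no direction for compound 3. The expected step is none beyond the scatter: no change at the digits printed from compound 2 to compound 3 (within the scatter). Compound 3 is therefore estimated at 16000 nM, with a range of 6000 nM to 45000 nM.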

Compound 3, half-maximal cytotoxic concentration: 9000 nM
Compound 3: middle estimate off by 1.8-fold (0.25 log units), on the high side; the range from low to high includes it.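

In this assay, for the compounds shown here, this is the first reading on the amine itself: a 1.8-fold lower number from compound 2 to compound 3 (0.25 log units; within the scatter). Pyrrolidin-1-yl, with its ring, and diethylamino, with no ring, are therefore not separated at this place on a saturated chain carbon bound to a carbonyl carbon. The larger step still lies with the whole side chain, since an at least 11-fold lower number from compound 1 to compound 3 (1.04 log units; beyond the scatter), so the diethylamino amide repeats on the nitro exchange what the pyrrolidin-1-yl amide showed; the size of this step has an open end, and the value of compound 1 is a limit, not a number: the limit of >= 100000 nM in this assay, at which 1 of the 3 values shown sits.

Open, from the compounds shown here alone, is whether a larger or hetero-atom-bearing amine, such as piperidin-1-yl or morpholin-4-yl, would stay with these two values. Also open, going by these compounds, is what a longer chain between the carbonyl and the amine, or a plain acetamide with no amine at all, would give.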